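Working notes: nitro in place of amino at the aryl ring

This account rests on a few compounds, and the source may have more. Where it says the series, first, only, none or still open, it means among the compounds named here.

Measured compounds:
compound 1, `C/C(=N\NC(=O)Nc1ccc(Br)cc1)c1ccccc1`, in a functional assay on the whole organism with Mus musculus as the target, in the maximal electroshock model, with a stated time of 0.5 h; a lower number here means that less compound is needed, a higher number that more compound is needed for the effect: 100 mg/kg
compound 2, `C/C(=N\NC(=O)Nc1ccc(Br)cc1)c1ccc(N)cc1`, in this assay: 300 mg/kg

Compound 2 stands at the highest of the two numbers in this assay; its nearest neighbour is compound 1, and the step of a 3.0-fold higher number from compound 1 to compound 2 (0.48 log units; beyond the scatter) lies beyond the scatter.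

Compound 3, `C/C(=N\NC(=O)Nc1ccc(Br)cc1)c1ccc([N+](=O)[O-])cc1`, is not yet measured. It differs from compound 2 in one place: nitro in place of amino on an aromatic carbon.

For the measured compounds named here, only one measured step exists, a 3.0-fold higher number from compound 1 to compound 2 (0.48 log units; beyond the scatter), and it concerns amino in place of hydrogen on an aromatic carbon, not nitro in place of amino. It shows that a change at this aromatic carbon can move the number beyond the scatter, but it gives no direction for the present exchange. Going by the values given here, no measured pair shows nitro in place of amino, so the expected step in this assay for compound 3 is small and its direction uncertain; the estimated step is a 1.5-fold lower number from compound 2 to compound 3 (0.18 log units; within the scatter). Compound 3 is therefore expected to give about 200 mg/kg in this assay, within a range of 100 mg/kg to 600 mg/kg.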

Compound 3, minimum effective dose: 300 mg/kg
Beside the measured number, compound 3's estimate is 1.5-fold (0.18 log units) below it; the measured number falls inside the stated range.
By their numbers in this assay, from the lowest: compound 1; then compounds 2 and 3 (each within the scatter of the next).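

In this assay, nitro in place of amino on the aromatic carbon gives no change at the digits printed from compound 2 to compound 3 (within the scatter), so the two groups cannot be told apart at this position, although nitro brings more heavy atoms and amino is the only one of the two with a hydrogen-bond donor. Nitro in place of hydrogen gives a 3.0-fold higher number from compound 1 to compound 3 (0.48 log units; beyond the scatter), which matches a 3.0-fold higher number from compound 1 to compound 2 (0.48 log units; beyond the scatter); a second substituent therefore lands on the same side of the unsubstituted compound 1, and neither substituted compound goes against this within the three compounds shown. The earlier pair showed this for amino alone, whereas the series now shows that a higher number than that of compound 1 is not specific to amino. No measurement at hand bears on why these numbers fall as they do.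

Whether any group at this aromatic carbon would match or lower the number of compound 1 stays open, as the compounds shown include no fluorine, methoxy or carboxylic acid there. Also open, from the compounds shown here alone, is whether the match between amino and nitro would hold with a chlorine or a methyl group in place of the bromine on the other aromatic ring.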